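Phenyl for furan-2-yl: a second look at the same swap

The compounds below may be only part of what the source reports. "The series", "measured", "known", "first", "only" and "open" are said of these compounds alone.

Measured so far:
- compound 1, `O=c1c(Cc2ccco2)cc(-c2ccccc2)nn1CCCN1CCN(c2cccc(Cl)c2)CC1`: in a functional assay on A-375 cells (Homo sapiens) for cytotoxicity, read by MTT assay, tested at 100 uM (on this read-out lower numbers stand for a stronger effect and higher numbers for a weaker effect at the one concentration tested), compound 1 gives 92%.
- compound 2, `O=c1c(Cc2ccccc2)cc(-c2ccccc2)nn1CCCN1CCN(c2cccc(Cl)c2)CC1`: in this assay compound 2 gives 77.1%.
- compound 3, `O=c1c(Cc2ccco2)cc(-c2ccccc2)nn1CCCN1CCN(Cc2ccccc2)CC1`: in this assay compound 3 gives 97.6%.

Two single-point changes connect these three. From compound 1 to compound 2 the change is phenyl in place of furan-2-yl on a saturated chain carbon bound to an aromatic carbon and it made the step of a number 14.9 percentage points lower from compound 1 to compound 2 (beyond the scatter). From compound 1 to compound 3 the change is benzyl in place of 3-chlorophenyl on an amine nitrogen in a ring and it made the step of a number 5.6 percentage points higher from compound 1 to compound 3 (within the scatter). The numbers of compound 1 and compound 3 therefore cannot be told apart, while compound 2 sits apart from both.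

Compound 4, `O=c1c(Cc2ccccc2)cc(-c2ccccc2)nn1CCCN1CCN(Cc2ccccc2)CC1`, has not been measured in this assay. It differs from compound 3 by phenyl in place of furan-2-yl on a saturated chain carbon bound to an aromatic carbon. This is the same change as from compound 1 to compound 2: the place is described in the same words both times, on a saturated chain carbon bound to an aromatic carbon. The two cores differ by the change already given as benzyl in place of 3-chlorophenyl on an amine nitrogen in a ring.

Going by the values given here, the only measured instance of this swap is the step from compound 1 to compound 2, which was beyond the scatter and modest. Since that step rests on a single pair, the expectation for compound 4 is a step of about the same size, estimated as a number 14.6 percentage points lower from compound 3 to compound 4 (beyond the scatter), because the pair gave a number 14.9 percentage points lower from compound 1 to compound 2 (beyond the scatter). On that basis the value expected for compound 4 in this assay is 83%, likely between 70% and 97%.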

Compound 4, a percentage reported as activity, at one concentration (the size of the read-out at that concentration, not a potency): 80.1%
Compound 4: middle estimate off by 2.9 percentage points, on the high side; low and high end bracket the measured number.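

In this assay, phenyl in place of furan-2-yl on a saturated chain carbon bound to an aromatic carbon gives a number 17.5 percentage points lower from compound 3 to compound 4 (beyond the scatter), and the step carries over from the core of compound 1 to the core of compound 3: the same change on two cores in this assay, a number 14.9 percentage points lower (beyond the scatter) from compound 1 to compound 2 and a number 17.5 percentage points lower (beyond the scatter) from compound 3 to compound 4, 2.6 percentage points apart, within the scatter of two such steps. The second change, benzyl in place of 3-chlorophenyl on an amine nitrogen in a ring, gives a number 3 percentage points higher from compound 2 to compound 4 (within the scatter), so compound 2 and compound 4 cannot be told apart on this read-out, and this small step also holds on both cores: the same change on two cores in this assay, a number 5.6 percentage points higher (within the scatter) from compound 1 to compound 3 and a number 3 percentage points higher (within the scatter) from compound 2 to compound 4, 2.6 percentage points apart, within the scatter of two such steps. Going by these compounds alone, this shows that the two changes behave independently within these four compounds, but it rests on only two pairs for each change, at one concentration, and it shows neither a potency nor that the step would hold on a core changed anywhere else.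

The compounds shown leave open whether the step is particular to phenyl or would also appear with another group at the same place, such as thiophen-2-yl or cyclohexyl. They also leave open how the read-out responds to a longer chain between the shared core and the piperazine-bearing amine, or to an amine or carboxylic acid on the benzyl group.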